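This account rests on a few compounds, and the source may have more. Where it says the series, first, only, none or still open, it means among the compounds named here.

Two compounds of the series have been run in a functional assay on cells for agonist activity at Glucose-dependent insulinotropic receptor (Homo sapiens), read by a luciferase reporter, with a stated time of 6 h (on this read-out higher numbers stand for an effect only at larger amounts of compound and lower numbers for an effect already at smaller amounts), so far. Compound 1 `CON(C)C(=O)c1ccc(-c2csc3c(OC4CCN(C(=O)OC(C)(C)C)CC4)ncnc23)cc1` gives 64 nM in this assay. Compound 2 `CON(C)C(=O)c1ccc(-c2ccc(OCC3CCN(C(=O)OC(C)(C)C)CC3)cn2)cc1F` gives 73 nM in this assay, which places it alongside compound 1 within the usual scatter of the measurement. Among the compounds with values here, no step between measured compounds of this set differs in only one place, so no directly counted step is available as a guide.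

Compound 3 `CON(C)C(=O)c1ccc(-c2ccc(OCC3CCN(C(=O)OC(C)C)CC3)cn2)cc1F` has not yet been run. It differs from compound 2 by hydrogen in place of methyl on a saturated chain carbon bound to an oxygen next to a carbonyl group and two saturated chain carbons; the carbamate end of the chain is thus shortened by one carbon and nothing else changes. With no measured step of this kind in the set, the expectation is a step of little size in this assay, in no fixed direction and most likely not beyond the scatter. For compound 3 the expected result is 90 nM, with a range from 35 nM to 250 nM, which corresponds to an estimated step of a 1.2-fold higher number from compound 2 to compound 3 (0.09 log units; within the scatter).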

Compound 3, half-maximal effective concentration: 92 nM
Estimate against measurement, compound 3: 1.0-fold (0.01 log units) below; the measured number falls inside the stated range.
By their numbers in this assay, from the lowest: compounds 1, 2 and 3 (each within the scatter of the next).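

In this assay, within the data shown here, the exchange of tert-butoxycarbonyl for isopropoxycarbonyl gives a 1.3-fold higher number from compound 2 to compound 3 (0.10 log units; within the scatter) and is the first one-place comparison available. At this saturated chain carbon, a methyl can therefore give way to hydrogen without a step beyond the scatter, so the full tert-butyl end is not needed to keep a number in the range of compound 2. No measurement at hand gives a reason for this result.

From the compounds shown here alone, it remains open whether the carbamate end can be shortened further, to ethoxycarbonyl or methoxycarbonyl, or replaced by a cyclopropyl group, an amide or a urea, without a step beyond the scatter. Going by these compounds, it also remains open whether the same exchange of tert-butyl for isopropyl would read alike on the core of compound 1.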